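The source may hold more compounds than are shown below. What is called first, only, known or untested is meant among the compounds shown, and "the series" means these compounds.

Working notes on the series: in a functional assay on A549 cells (Homo sapiens) for cytotoxicity, read by MTT assay, with a stated time of 48 h (a lower number here means a stronger inhibitor, a higher number a weaker inhibitor), compound 1 `COc1ccc(/C=C/c2cc(OC)c(OC)c(OC)c2-c2ccc(F)c(F)c2)cc1` gives 7500 nM, compound 2 `COc1ccc(/C=C/c2cc(OC)c(OC)c(OC)c2-c2ccccc2)cc1` gives 36000 nM, and compound 3 `COc1ccc(/C=C/c2cc(OC)c(OC)c(OC)c2-c2ccc3ccccc3c2)cc1` gives 14000 nM. Compound 3 stands within the scatter of compound 1, with a 1.9-fold higher number from compound 1 to compound 3 (0.27 log units; within the scatter), and clearly apart from compound 2, with a 2.6-fold lower number from compound 2 to compound 3 (0.41 log units; beyond the scatter).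

Compound 4 `COc1ccc(/C=C/c2cc(OC)c(OC)c(OC)c2-c2ccc(Cl)cc2)cc1` carries 4-chlorophenyl in place of naphthalen-2-yl on an aromatic carbon. Within the data shown here, no chlorinated compound has been measured, so the guide is the set of swaps at this same place. Removing the two fluorines gives a 4.8-fold higher number from compound 1 to compound 2 (0.68 log units; beyond the scatter), a modest step, so a halogen-bearing phenyl may sit nearer compound 1 than compound 2, although this rests on one pair alone. With compound 3 already close to compound 1, no step beyond the scatter is expected in this assay, though a drift toward compound 2 cannot be excluded. The expected change is a 1.3-fold lower number from compound 3 to compound 4 (0.10 log units; within the scatter). Compound 4 is estimated at 11000 nM, with an expected range of 5000 nM to 28000 nM.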

Compound 4, half-maximal inhibitory concentration: 30000 nM
For compound 4 the middle estimate is 2.7-fold (0.44 log units) below the measured one; the measured number lies above the stated range.
By their numbers in this assay, from the lowest: compounds 1 and 3 (each within the scatter of the next); then compounds 4 and 2 (each within the scatter of the next).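

In this assay, chloro in place of hydrogen gives a 1.2-fold lower number from compound 2 to compound 4 (0.08 log units; within the scatter), so at this position a halogen on the phenyl does not by itself reproduce what the two fluorines of compound 1 show. 4-Chlorophenyl stands apart from 3,4-difluorophenyl, with a 4.0-fold higher number from compound 1 to compound 4 (0.60 log units; beyond the scatter), and from naphthalen-2-yl, with a 2.1-fold higher number from compound 3 to compound 4 (0.33 log units; beyond the scatter), which places the two lower numbers with compound 1 and compound 3 only. Nothing in the data shown explains these differences.

From the compounds shown here alone, compound 1 and compound 4 differ in both the identity and the number of their halogens, so the contribution of each remains open. Also open, going by these compounds, is how a phenyl carrying an amine, a carboxylic acid or a 4-fluoro group would behave at this position.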